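This account rests on a few compounds, and the source may have more. Where it says the series, first, only, none or still open, it means among the compounds named here.

Measured so far in a functional assay on SF-295 cells (Homo sapiens) for antiproliferative activity, with a stated time of 48 h; on this read-out lower numbers stand for stronger inhibition of growth and higher numbers for weaker inhibition of growth: compound 1 `Cc1cc(O)c(C2=NN(c3ccc(S(N)(=O)=O)cc3)C(c3ccccc3O)C2)cc1Cl` gives 3670 nM; compound 2 `Cc1cc(O)c(C2=NN(c3ccc(S(N)(=O)=O)cc3)C(c3ccccc3Cl)C2)cc1Cl` gives 3180 nM; compound 3 `COc1ccc(C2CC(c3cc(Cl)c(C)cc3O)=NN2c2ccc(S(N)(=O)=O)cc2)cc1OC` gives 6240 nM.

Compound 1 has the second highest of the three numbers. Its nearest neighbour is compound 2, with a 1.2-fold lower number from compound 1 to compound 2 (0.06 log units; within the scatter); its furthest is compound 3, with a 1.7-fold higher number from compound 1 to compound 3 (0.23 log units; within the scatter). Compound 4 `COc1ccc(C2CC(c3cc(Cl)c(C)cc3O)=NN2c2ccc(S(N)(=O)=O)cc2)c(OC)c1OC` is not yet measured; it differs from compound 1 by 2,3,4-trimethoxyphenyl in place of 2-hydroxyphenyl on a saturated ring carbon. Within the data shown here, the steps that bear on this change are those that put a methoxylated ring on the same saturated ring carbon: the step from compound 1 to compound 3 noted above, and a 2.0-fold higher number from compound 2 to compound 3 (0.29 log units; within the scatter), both within the scatter. A step of similar size, if any, is therefore expected here, and none beyond the scatter. Compound 4 is expected at 5500 nM, between 2300 nM and 13000 nM, that is a 1.5-fold higher number from compound 1 to compound 4 (0.18 log units; within the scatter).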

Compound 4, concentration for total growth inhibition: 3960 nM
Estimate against measurement, compound 4: 1.4-fold (0.14 log units) above; measured number inside the range.
By their numbers in this assay, from the lowest: compounds 2, 1, 4 and 3 (each within the scatter of the next).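

In this assay, the 2,3,4-trimethoxyphenyl group on this saturated ring carbon stays within the scatter of both the 2-hydroxyphenyl group (a 1.1-fold higher number from compound 1 to compound 4 (0.03 log units; within the scatter)) and the 2-chlorophenyl group (a 1.2-fold higher number from compound 2 to compound 4 (0.10 log units; within the scatter)), so this position has now taken three methoxy groups and lost the hydroxy donor without a step beyond the scatter. One further methoxy on the aromatic ring also stays within the scatter (a 1.6-fold lower number from compound 3 to compound 4 (0.20 log units; within the scatter)). No measured evidence bears on this result. Open, as far as these compounds go, is whether an amine or a carboxylic acid on this ring, or a longer chain in place of it, would give a step beyond the scatter.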